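Benzyl-triazole chalcone ethers: bromo to fluoro on the benzyl ring

The compounds below may be only part of what the source reports. "The series", "measured", "known", "first", "only" and "open" are said of these compounds alone.

Measured so far in a functional assay on A549 cells (Homo sapiens) for inhibition, read by MTT assay, with a stated time of 48 h, tested at 10 uM; on this read-out lower numbers stand for less inhibition of growth and higher numbers for more inhibition of growth at the one concentration tested:
Compound 1 `O=C(/C=C/c1ccc(OCc2cn(Cc3cccc(Br)c3)nn2)cc1)c1ccc(Br)cc1`: 44%
Compound 2 `COc1ccc(C(=O)/C=C/c2ccc(OCc3cn(Cc4ccccc4Br)nn3)cc2)cc1`: 52%
Compound 3 `COc1ccc(C(=O)/C=C/c2ccc(OCc3cn(Cc4cccc(Br)c4)nn3)cc2)cc1`: 47%

Compound 3 stands second highest of the three numbers in this assay; its nearest neighbour is compound 1, the furthest compound 2, and both gaps lie within the scatter, so no order among the three can be read. The two measured steps are a number 3 percentage points higher from compound 1 to compound 3 (within the scatter) and a number 5 percentage points lower from compound 2 to compound 3 (within the scatter), each within the scatter.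

Compound 4 `COc1ccc(C(=O)/C=C/c2ccc(OCc3cn(Cc4ccccc4F)nn3)cc2)cc1` differs from compound 3 in one place: 2-fluorophenyl in place of 3-bromophenyl on a saturated chain carbon bound to an aromatic nitrogen. Going by the values given here, of the measured steps only the one from compound 2 to compound 3 touches the same place, and it was small, a number 5 percentage points lower from compound 2 to compound 3 (within the scatter); no measured pair shows bromine exchanged for fluorine on this ring. On this basis no step beyond the scatter is expected in this assay, in either direction: the expected step is a number 2 percentage points higher from compound 3 to compound 4 (within the scatter). Compound 4 is therefore estimated at 49%, with a range of 35% to 63%.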

Compound 4, percent growth inhibition at one concentration: 21%
Estimate against measurement, compound 4: 28 percentage points above; measured number outside the range, below it.
By their numbers in this assay, from the lowest: compound 4; then compounds 1, 3 and 2 (each within the scatter of the next).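

On the benzyl ring, the identity of the halogen now registers in this assay: the clean exchange of fluoro for bromo on an aromatic carbon gives a number 31 percentage points lower from compound 2 to compound 4 (beyond the scatter), whereas the earlier change of bromine's place gave only a number 5 percentage points lower from compound 2 to compound 3 (within the scatter). The change from 3-bromophenyl to 2-fluorophenyl, with a number 26 percentage points lower from compound 3 to compound 4 (beyond the scatter), therefore matches the loss seen on exchanging the halogen alone, and among these compounds the position of the substituent adds no separate step. No measurement available here bears on the origin of this loss.

Still open, from the compounds shown here alone, is whether the lower number is specific to fluorine at this place, as a 3-fluorophenyl, 2-chlorophenyl or unsubstituted phenyl group would help to show. Also open, going by these compounds, is whether the step carries over to the core of compound 1, with bromo in place of methoxy.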